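Trifluoromethoxy for trifluoromethyl: from compound 3 to compound 4

The source may hold more compounds than are shown below. What is called first, only, known or untested is meant among the compounds shown, and "the series" means these compounds.

Values in an ADME assay on microsomes from liver (Canis lupus familiaris) for metabolic stability, with a stated time of 10 min; on this read-out lower numbers stand for a less stable compound and higher numbers for a more stable compound:
- compound 1 `Fc1ccccc1-c1ccc2[nH]c(C3=NOC4(CCCCC4)C3)nc2c1`: 47%
- compound 2 `FC(F)(F)Oc1ccccc1-c1ccc2[nH]c(C3=NOC4(CCCCC4)C3)nc2c1`: 81%
- compound 3 `Fc1cccc(C(F)(F)F)c1-c1ccc2[nH]c(C3=NOC4(CCCCC4)C3)nc2c1`: 65%

Of the three values, compound 3 at 65% is the middle one. The highest is that of compound 2 at 81%. The lowest is that of compound 1 at 47%.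

Compound 4 `Fc1cccc(OC(F)(F)F)c1-c1ccc2[nH]c(C3=NOC4(CCCCC4)C3)nc2c1` is still unmeasured in this assay. It differs from compound 3 as follows: trifluoromethoxy in place of trifluoromethyl on an aromatic carbon. The group enters ortho to a large group and meta to a fluoro group.

For the measured compounds named here, two measured steps bear on this change. Trifluoromethoxy in place of fluoro gave a number 34 percentage points higher from compound 1 to compound 2 (beyond the scatter). Trifluoromethyl in place of hydrogen gave a number 18 percentage points higher from compound 1 to compound 3 (beyond the scatter). Neither step swaps these two groups directly, and compound 2 lacks the fluoro group that compound 3 keeps, so only part of the larger step is expected to carry over.

The expected change is a small rise, a number 9 percentage points higher from compound 3 to compound 4 (within the scatter), which may not clear the scatter. For compound 4 the estimate is 74%, with an expected range of 60% to 88%.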

Compound 4, percent of the compound remaining: 73%
Beside the measured number, compound 4's estimate is 1 percentage points above it; low and high end bracket the measured number.
By their numbers in this assay, from the lowest: compound 1; then compounds 3, 4 and 2 (each within the scatter of the next, the first and the last beyond it).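

In this assay the direct exchange of trifluoromethyl for trifluoromethoxy, ortho to a large group and meta to a fluoro group, gives a number 8 percentage points higher from compound 3 to compound 4 (within the scatter) and so does not separate the two groups at this place. The added fluoro group also makes no resolved difference among the trifluoromethoxy compounds, with a number 8 percentage points lower from compound 2 to compound 4 (within the scatter) as the step. Against the compound carrying only hydrogen at this place the gain stands clear, with a number 26 percentage points higher from compound 1 to compound 4 (beyond the scatter) as the step, so trifluoromethoxy keeps its gain when the fluoro group is present, and compound 3 shows such a gain for trifluoromethyl as well.

Nothing at hand gives a reason for any of these steps. Open, going by these compounds, is whether a smaller group such as methyl or chloro, or a polar one such as an amine or a nitrile, would hold the number at this place.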